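The source may report more compounds than this note shows. Statements on the series, on what has been measured and on what is new or still open speak of the compounds shown alone.

Measured so far in a functional assay on the whole organism for inhibition, with Rattus norvegicus as the target, at a dose of 30 mg/kg; a higher number here means more inhibition at the dose given (going by the name of the read-out), a lower number less inhibition:
compound 1 `C/N=C(\S)n1ncnc1N` — 93%
compound 2 `CCC/N=C(\S)n1ncnc1N` — 93%

Compound 2 stands level with compound 1 at the digits shown; the step of no change at the digits printed from compound 1 to compound 2 (within the scatter) is within the scatter, so the two values carry no order between them.

Compound 3 `CCCC/N=C(\S)n1ncnc1N` is the next member. Its difference from compound 2, computed from the two structures: methyl in place of hydrogen on a saturated chain carbon, three bonds along the chain from a double-bonded nitrogen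

Among the compounds with values here, one measured step bears on this change: the step from compound 1 to compound 2 also extended the saturated chain on the carbon bound to the double-bonded nitrogen, and it gave no change at the digits printed from compound 1 to compound 2 (within the scatter) in this assay. Adding one further methyl along the same chain is a smaller change than that one, and that one left the read-out unchanged. On these two compounds alone, then, no step beyond the scatter is expected in this assay for compound 3, in either direction; the series is too short to say more.

Compound 3 is therefore estimated at 91%, with a range of 78% to 99%. The expected step is a number 2 percentage points lower from compound 2 to compound 3 (within the scatter).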

Compound 3, a percentage reported as inhibition, in the whole organism at one dose (the size of the read-out at that dose, not a potency): 21%
Compound 3: the middle estimate sits 70 percentage points above what was measured; measured number outside the range, below it.
By their numbers in this assay, from the lowest: compound 3; then compounds 1 and 2 (each within the scatter of the next).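

In this assay, the saturated chain proves sensitive to its length at this position: methyl in place of hydrogen, three bonds along the chain from a double-bonded nitrogen, gives a number 72 percentage points lower from compound 2 to compound 3 (beyond the scatter), whereas the earlier extension gave no change at the digits printed from compound 1 to compound 2 (within the scatter). Read from the shortest chain, propyl in place of hydrogen on the saturated chain carbon bound to a double-bonded nitrogen gives a number 72 percentage points lower from compound 1 to compound 3 (beyond the scatter), so across these three compounds the read-out does not fall evenly with chain length, and the whole of the fall lies in the final methyl. Nothing available here accounts for this drop in the whole-organism read-out.

The three compounds leave open whether a longer chain such as pentyl stays as low as compound 3 or falls further, and whether a branched isobutyl group, which would also extend the chain from compound 2, gives the same fall. On these data alone, since the read-out comes from a single dose and is not a potency, it also remains open how compound 3 compares with compound 2 at other doses.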